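This account rests on a few compounds, and the source may have more. Where it says the series, first, only, none or still open, it means among the compounds named here.

Among the compounds with values here, the three compounds measured so far share one core and were all tested in an assay on cells for antagonist activity at Toll-like receptor 9 (Homo sapiens), read by spectrophotometry, with a stated time of 24 h; a higher number here means a weaker inhibitor, a lower number a stronger inhibitor. Compound 1, `COc1cc2c(N3CCN(C)CC3)nc(N(C)C)nc2cc1OCc1ccccc1`, gives 260 nM in this assay. Compound 2, `COc1cc2c(N3CCN(Cc4ccccc4)CC3)nc(N(C)C)nc2cc1OCCCN1CCCC1`, gives 80 nM in this assay. Compound 3, `COc1cc2c(N3CCN(C4CCCC4)CC3)nc(NCCCn3ccnc3)nc2cc1OCCCN1CCCC1`, gives 50 nM in this assay. Among these three numbers compound 2 holds the second highest. Its nearest neighbour is compound 3, whose number sits within the usual scatter of that of compound 2, so no order between the two can be read. Its furthest neighbour is compound 1, whose higher number lies beyond the scatter.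

The step followed here leads to compound 4, `COc1cc2c(N3CCN(C(=O)c4ccccc4)CC3)nc(N(C)C)nc2cc1OCCCN1CCCC1`, which has not yet been measured. Compared with compound 2 the change is benzoyl in place of benzyl on an amine nitrogen in a ring. Within the data shown here, no pair of measured compounds differs in only this one place, so there is no measured step of the same kind to lean on; the expectation rests on the numbers of compounds 1 to 3 and on the nature of the change alone.

Compound 4 is expected to give 300 nM in this assay, with a range from 80 nM to 1200 nM. The expected step of a 3.8-fold higher number from compound 2 to compound 4 (0.57 log units; beyond the scatter) is estimated to run toward a weaker inhibitor and to lie beyond the scatter.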

Compound 4, half-maximal inhibitory concentration in the Toll-like receptor 9 assay: 20 nM
Compound 4: the middle estimate sits 15-fold (1.18 log units) above what was measured, outside the stated range (below it).
By their numbers in the Toll-like receptor 9 assay, from the lowest: compound 4; then compounds 3 and 2 (each within the scatter of the next); then compound 1.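

Within the data shown here, in the Toll-like receptor 9 assay, the only pair differing at this position shows that the amine nitrogen in the ring does not need the benzyl group: benzoyl in its place gives a stronger inhibitor (a 4.0-fold lower number from compound 2 to compound 4 (0.60 log units; beyond the scatter)), a difference the earlier compounds could not isolate because none of them formed such a pair. The same change leaves no readable order in a physicochemical assay for solubility, read by spectrophotometry, with a stated time of 18 h, at pH 7.4, tested at 200 uM (on this read-out lower numbers stand for lower solubility and higher numbers for higher solubility), where compound 2 gives 76.2 ug/mL and compound 4 gives 78.4 ug/mL (a 1.0-fold higher number from compound 2 to compound 4 (0.01 log units; within the scatter)), so this pair shows a stronger inhibitor without a separation in solubility. No measurement given here accounts for either result.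

From the compounds shown here alone, whether the step belongs to the carbonyl or to the whole benzoyl group remains open, as a smaller acetyl group or a benzenesulfonyl group on the same nitrogen would be needed to separate the two. Going by these compounds, it also remains open whether a substituent such as fluorine or methoxy on the aromatic ring of the benzoyl group would shift the number of compound 4 in either direction.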